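The source may hold more compounds than are shown below. What is called first, only, known or untested is meant among the compounds shown, and "the series" means these compounds.

Among the compounds with values here, compound 2 `CC1CCN(C(=O)N2CC(c3nc(-c4cccc(Cl)c4)no3)C2)CC1` is the one compound here with a number in an assay on HEK293 cells for positive allosteric modulation of metabotropic glutamate receptor 5 (Homo sapiens), read by FLIPR (on this read-out lower numbers stand for an effect already at smaller amounts and higher numbers for an effect only at larger amounts of compound), where compound 2 gives 865 nM. Compound 1 `O=C(c1ccccc1F)N1CC(c2nc(-c3cccc(Cl)c3)no2)C1` reaches only the assay limit in this assay, at > 10000 nM. Within the data shown here, the single measured step runs an at least 11-fold lower number from compound 1 to compound 2 (1.06 log units; beyond the scatter), and its size rests on (the limit of > 10000 nM in this assay, at which 1 of the 2 values shown sits). Compound 3 `O=C([C@H]1CC2CCC1C2)N1CC(c2nc(-c3cccc(Cl)c3)no2)C1` differs from compound 2 by a group of 7 heavy atoms (7 carbon; 2 five-membered non-aromatic rings of carbon only) in place of a group of 7 heavy atoms (6 carbon, 1 nitrogen; one six-membered non-aromatic ring with 1 hetero atom), on a carbonyl carbon. The measured step touches the same carbonyl carbon but replaces an aromatic group with a cyclic amine, so it does not fix the direction of this swap. Compound 3 is therefore expected near compound 2, with 1200 nM estimated between 400 nM and 4000 nM. The implied change, a 1.4-fold higher number from compound 2 to compound 3 (0.14 log units; within the scatter), is expected to stay within the scatter.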

Compound 3, half-maximal effective concentration: 74 nM
Estimate against measurement, compound 3: 16-fold (1.21 log units) above; measured number below the stated range.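

At the carbonyl carbon, the bicyclic all-carbon group of compound 3 replaces 4-methylpiperidin-1-yl with no change in heavy-atom count, and this assay shows a 12-fold lower number from compound 2 to compound 3 (1.07 log units; beyond the scatter). The earlier step showed a gain for the cyclic amine over 2-fluorophenyl, whereas this one shows that the cyclic amine is not the best group here, and that a group with no ring nitrogen can give a lower number. The step of an at least 130-fold lower number from compound 1 to compound 3 (2.13 log units; beyond the scatter) gives only a bound on the full span at this position, since compound 1 sits at an assay limit: the limit of > 10000 nM in this assay, at which 1 of the 3 values shown sits.

The compounds shown cannot separate the loss of the ring nitrogen from the change of ring system, as both change together in this step. As far as these compounds go, whether cyclohexyl or unsubstituted piperidin-1-yl would read closer to compound 3 or to compound 2 stays open, as does the effect of the opposite configuration at the defined stereocentre of compound 3.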